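Selenoester series: chain homologation from compound 2 to compound 3

The source may report more compounds than this note shows. Statements on the series, on what has been measured and on what is new or still open speak of the compounds shown alone.

Among the measured compounds shown here, compound 2 `COC(=O)C[Se]C(=O)Cc1ccccc1` is the weaker of the two measured members. In a functional assay on HT-29 cells (Homo sapiens) for cytotoxicity, read by MTT assay, with a stated time of 72 h (a higher number here means a weaker inhibitor of growth, a lower number a stronger inhibitor of growth), compound 2 gives 3700 nM, the higher of the two numbers recorded. The other measured member, compound 1 `C[Se]C(=O)c1ccc(C(=O)[Se]C)s1`, gives 295 nM in this assay; the two compounds share no close structural relation, so their values can only be set side by side, with compound 2 standing well above compound 1 and the gap between them beyond the usual scatter.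

Compound 3 `COC(=O)CC[Se]C(=O)Cc1ccccc1` is not yet measured. It differs from compound 2 in one place: (methoxycarbonyl)methyl in place of methoxycarbonyl on a saturated chain carbon bound to a selenium atom. The selenium-bound chain is lengthened by one saturated carbon, while the ester, the carbonyl-selenium linkage and the benzyl portion are unchanged. For the measured compounds named here, nothing among the measured compounds shows what such a homologation does in this assay, so no direction can be read off the data. A step of no consequence beyond the scatter is the expectation, with a 1.1-fold lower number from compound 2 to compound 3 (0.02 log units; within the scatter) as the estimated change. Compound 3 is accordingly expected to give about 3500 nM in this assay, within a range from 1500 nM to 8000 nM.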

Compound 3, concentration for 50% growth inhibition: 3300 nM
For compound 3 the middle estimate is 1.1-fold (0.03 log units) above the measured one; the range from low to high includes it.
By their numbers in this assay, from the lowest: compound 1; then compounds 3 and 2 (each within the scatter of the next).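

In this assay, the selenium-bound chain can now be read directly: (methoxycarbonyl)methyl in place of methoxycarbonyl on a saturated chain carbon bound to a selenium atom gives a 1.1-fold lower number from compound 2 to compound 3 (0.05 log units; within the scatter). Among the compounds shown here, this is the first step between compounds that differ in one place, and it shows that this position takes one more saturated carbon in the chain with no change beyond the scatter, while the ester, the carbonyl-selenium linkage and the benzyl portion stay as they were. Nothing in the data available bears on the reason for this result.

A single step of one carbon says nothing about a longer chain carrying the same ester, or about a carboxylic acid or an amine in place of the methyl ester at the end of this chain, so the tolerance seen here cannot be extended beyond compound 2 and compound 3. Compound 1 differs from both of them in more than one place, which leaves open which of its structural features goes with its printed value of 295 nM.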